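Moving one trifluoromethoxy group: little change expected

The source may hold more compounds than are shown below. What is called first, only, known or untested is meant among the compounds shown, and "the series" means these compounds.

In a functional assay on CWR22R cells (Homo sapiens) for antiproliferative activity, read by propidium iodide staining, with a stated time of 96 h (on this read-out lower numbers stand for stronger inhibition and higher numbers for weaker inhibition), compound 1 `CC(O)(CS(=O)(=O)c1cccc(S(F)(F)(F)(F)F)c1)C(=O)Nc1cccc(S(F)(F)(F)(F)F)c1` gives 15400 nM and compound 2 `CC(O)(CS(=O)(=O)c1cccc(C(F)(F)F)c1)C(=O)Nc1cccc(S(F)(F)(F)(F)F)c1` gives 24600 nM while compound 3 `CC(O)(CS(=O)(=O)c1ccc(OC(F)(F)F)cc1)C(=O)Nc1cccc(S(F)(F)(F)(F)F)c1` gives 31200 nM as its reading. Compound 3 therefore sits within the usual scatter of compound 2, and its number is clearly higher than that of compound 1.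

Compound 4 `CC(O)(CS(=O)(=O)c1cccc(OC(F)(F)F)c1)C(=O)Nc1cccc(S(F)(F)(F)(F)F)c1` has the same atoms as compound 3, joined differently: 3-(trifluoromethoxy)phenyl in place of 4-(trifluoromethoxy)phenyl on a sulfonyl sulfur with 3-(trifluoromethoxy)phenyl in place of 4-(trifluoromethoxy)phenyl on a sulfonyl sulfur.

The expectation rests on two measured steps, a 1.6-fold higher number from compound 1 to compound 2 (0.20 log units; within the scatter) for a swap of one group on an aromatic carbon and a 1.3-fold higher number from compound 2 to compound 3 (0.10 log units; within the scatter) for a swap of the ring on the sulfonyl sulfur, and both stayed within the scatter. No shift beyond the scatter is therefore expected, and the estimated step is a 1.4-fold lower number from compound 3 to compound 4 (0.13 log units; within the scatter) in this assay for this move of one group. For compound 4 the estimated value is 23000 nM with an expected range from 12000 nM to 42000 nM in this measurement.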

Compound 4, half-maximal inhibitory concentration: 20100 nM
Beside the measured number, compound 4's estimate is 1.1-fold (0.06 log units) above it, and the stated range covers the measured number.
By their numbers in this assay, from the lowest: compounds 1, 4, 2 and 3 (each within the scatter of the next, the first and the last beyond it).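

In this assay, moving the group from 4-(trifluoromethoxy)phenyl to 3-(trifluoromethoxy)phenyl on the sulfonyl sulfur gives a 1.6-fold lower number from compound 3 to compound 4 (0.19 log units; within the scatter) and so does not separate the two placements on this read-out. Compound 4 also stays close to its neighbours with a different group on the same ring: trifluoromethoxy in place of trifluoromethyl gives a 1.2-fold lower number from compound 2 to compound 4 (0.09 log units; within the scatter) as the step, and the same group in place of the larger fluorinated sulfur group gives a 1.3-fold higher number from compound 1 to compound 4 (0.12 log units; within the scatter) as the step, so compound 4 sits within the scatter of all three earlier compounds. Nothing measured here gives a reason for these small steps.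

As far as these compounds go, whether an amine or a carboxylic acid on this ring would move the number beyond the scatter remains open. So does whether these small steps would hold with a different group elsewhere in the molecule.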